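A few compounds are considered here, and "the series" means these few. Any claim that something is new, unique, unknown or untested is made for them only; others in the source may bear on it.

Compound 1 `Cc1cc(-c2ncnc3c2ncn3C2O[C@H](CO)[C@@H](O)[C@H]2O)on1` gives "not active" (no number reported) in a functional assay on CCRF-CEM cells (Homo sapiens) for inhibition; a higher number here means a weaker inhibitor, a lower number a stronger inhibitor.
Compound 2 `Cc1ccsc1-c1ncnc2c1ncn2C1O[C@H](CO)[C@@H](O)[C@H]1O` gives 2500 nM in this assay.

Going by the values given here, compound 2 stands as the only compound with a numerical result in this assay; compound 1 is recorded as not active without a number, so nothing beyond that can be said of how the two compare. Compound 3 `Cn1cccc1-c1ncnc2c1ncn2C1O[C@H](CO)[C@@H](O)[C@H]1O` has not yet been measured. It differs from compound 2 by a single exchange: 1-methyl-1H-pyrrol-2-yl in place of 3-methylthiophen-2-yl on an aromatic carbon. Among the compounds with values here, no step between two measured compounds is available to calibrate an exchange of this kind, and compound 1, which carries a different group, shows that activity can be lost altogether. The expectation for compound 3 in this assay is therefore a step of a 1.6-fold higher number from compound 2 to compound 3 (0.20 log units; within the scatter), a modest loss that may well stay within the scatter, with a real chance that only a limit and no number is reported. Compound 3 is estimated at 4000 nM, with a range from 1000 nM to 20000 nM.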

Compound 3, half-maximal inhibitory concentration: 2000 nM
Compound 3: the middle estimate sits 2.0-fold (0.30 log units) above what was measured, and the stated range covers the measured number.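

In this assay, going by these compounds alone, 1-methyl-1H-pyrrol-2-yl in place of 3-methylthiophen-2-yl on this aromatic carbon gives a 1.3-fold lower number from compound 2 to compound 3 (0.10 log units; within the scatter), the first step that can be read at this position: one five-membered aromatic ring with sulfur as its hetero atom gives way to one with nitrogen, with no difference beyond the scatter. Compound 1, which carries a different group at the same place, still gives "not active" (no number reported), so the two numbers from compound 2 and compound 3 do not extend to every five-membered aromatic group on this carbon. Nothing measured on the compounds accounts for the closeness of these two results or for the lack of a number for compound 1.

The compounds shown leave open what the methyl contributes in either ring, since neither an unsubstituted thiophen-2-yl nor a 1H-pyrrol-2-yl group appears among them. They also leave open whether this carbon needs a five-membered aromatic ring at all, as a phenyl ring, an amine or a short alkyl chain in its place would test.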